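The source may hold more compounds than are shown below. What is called first, only, known or untested is meant among the compounds shown, and "the series" means these compounds.

Compound 2 `CC(C)=CC[C@@H](OC(=O)C1CCCO1)C1=CC(=O)c2c(O)ccc(O)c2C1=O` carries a (oxolan-2-yl)carbonyl group on the oxygen of its side chain, and in a functional assay on DU-145 cells (Homo sapiens) for cytotoxicity, read by MTT assay (a higher number here means a weaker inhibitor, a lower number a stronger inhibitor), compound 2 gives 10500 nM, the lowest of the two numbers in hand. Compound 3 `CCCCC(C)(O)CC(=O)O[C@H](CC=C(C)C)C1=CC(=O)c2c(O)ccc(O)c2C1=O`, with a 2-hydroxy-2-methylhexyl group on that carbonyl carbon, gives 76500 nM in this assay. Compound 1 `CC(C)=CC[C@@H](OC(=O)CC(C)(O)c1ccccc1)C1=CC(=O)c2c(O)ccc(O)c2C1=O` reaches only a limit of this assay, > 100000 nM (the limit of > 100000 nM in this assay, at which 1 of the 3 values shown sits). Compound 4 `CC(C)=CC[C@@H](OCCO)C1=CC(=O)c2c(O)ccc(O)c2C1=O` is not yet measured; it differs from compound 2 by 2-hydroxyethyl in place of (oxolan-2-yl)carbonyl on an oxygen on a saturated carbon. Among the measured compounds shown here, two measured steps touch the same place: an at least 9.5-fold lower number from compound 1 to compound 2 (0.97 log units; beyond the scatter) and a 7.3-fold higher number from compound 2 to compound 3 (0.86 log units; beyond the scatter), both showing that the oxolan-2-yl group on the carbonyl carbon goes with a lower number than the longer 2-hydroxy-2-phenylpropyl or 2-hydroxy-2-methylhexyl groups. For the measured compounds named here, no measured step removes the carbonyl itself, so the move to a 2-hydroxyethyl group is untested ground. A modest rise in the number is expected, a 2.9-fold higher number from compound 2 to compound 4 (0.46 log units; beyond the scatter). Compound 4 is therefore estimated at 30000 nM, with a range from 8000 nM to 100000 nM.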

Compound 4, half-maximal inhibitory concentration: 9900 nM
Beside the measured number, compound 4's estimate is 3.0-fold (0.48 log units) above it; the measured number falls inside the stated range.
By their numbers in this assay, from the lowest: compounds 4 and 2 (each within the scatter of the next); then compound 3. At a limit, above all of these: compound 1.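

Replacing the whole (oxolan-2-yl)carbonyl group with 2-hydroxyethyl gives a 1.1-fold lower number from compound 2 to compound 4 (0.03 log units; within the scatter) and shows that, in this cytotoxicity assay, neither the carbonyl nor the ring of that group has to be present for the number to stay where it is. The second new comparison, a 7.7-fold lower number from compound 3 to compound 4 (0.89 log units; beyond the scatter) and beyond the scatter, shows that the gap between compound 3 and the lower-numbered compounds does not depend on keeping a carbonyl on this oxygen. A group on this oxygen can therefore differ greatly in its atoms and still give a number within the scatter of compound 2.

Going by these compounds, how an amine in place of the hydroxyl of the 2-hydroxyethyl group, or a longer chain carrying that hydroxyl, would read remains open. Nothing shown explains why these two different groups read alike.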